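A few compounds are considered here, and "the series" means these few. Any claim that something is new, unique, unknown or untested is made for them only; others in the source may bear on it.

Two dichloroacetamides sit on the same anilide core, and only one of them has a number. Compound 1, `N#Cc1cccc(NC(=O)C(Cl)Cl)c1`, carries a nitrile on the ring, and for compound 1 the outcome in a functional assay on BGC-823 cells (Homo sapiens) for antiproliferative activity, read by MTT assay, with a stated time of 72 h (a higher number here means a weaker inhibitor, a lower number a stronger inhibitor), is "not determined" (no result reported). Compound 2, `O=C(Nc1cccc(C(F)(F)F)c1)C(Cl)Cl`, carries a trifluoromethyl instead, and in this assay compound 2 gives 143000 nM, which marks it as a weak inhibitor of cell growth; it is the only measured entry, so it stands alone rather than above or below anything.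

Compound 3, `O=C(Nc1cccc(OC(F)(F)F)c1)C(Cl)Cl`, is the next step from compound 2. The change is trifluoromethoxy in place of trifluoromethyl on an aromatic carbon. Among the measured compounds shown here, no pair of measured compounds shows what such a swap does here, so there is no measured step to lean on.

With compound 2 at 143000 nM as the only anchor, the swap is expected to move the number little, with a step from compound 2 to compound 3 of about a 1.0-fold higher number from compound 2 to compound 3 (0.02 log units; within the scatter), not beyond the usual scatter. Compound 3 is therefore estimated at 150000 nM, somewhere between 50000 nM and 400000 nM.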

Compound 3, half-maximal inhibitory concentration: 142000 nM
Compound 3: middle estimate off by 1.1-fold (0.02 log units), on the high side; the measured number falls inside the stated range.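

In this assay, among the compounds shown here, this is the first measured change at this place on the ring, and it gives a 1.0-fold lower number from compound 2 to compound 3 (0.00 log units; within the scatter), so the two groups cannot be told apart in this read-out. Trifluoromethoxy has 5 heavy atoms and 1 hydrogen-bond acceptor, while trifluoromethyl has 4 heavy atoms and no hydrogen-bond acceptor, yet that difference in make-up, on an aromatic carbon meta to a group of 6 heavy atoms, comes with no step beyond the scatter in this pair. Nothing measured here explains why the two compounds read alike.

For the compounds shown here, the nitrile of compound 1 offers no step to read, so this single pair is all there is to go on for this place, and it says nothing about the same swap elsewhere on the ring or on another core. Going by these compounds, whether an amine, a carboxylic acid or a longer chain at this place would give a number beyond the scatter from that of compound 2 stays open.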